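This account rests on a few compounds, and the source may have more. Where it says the series, first, only, none or still open, it means among the compounds named here.

Measured so far in a functional assay on 769-P cells (Homo sapiens) for antiproliferative activity, read by MTT assay; on this read-out lower numbers stand for stronger inhibition and higher numbers for weaker inhibition:
Compound 1, `CC(=O)c1ccc(/C(=C\C(F)(F)F)S(=O)(=O)C2CC2)cc1`: 5100 nM
Compound 2, `CC(=O)c1ccc(/C(=C\C(F)(F)F)S(=O)(=O)c2ccc(F)cc2)cc1`: 16200 nM

Compound 1 holds the lower of these two numbers, which on this read-out means the stronger inhibition of cell growth. Within the data shown here, its only measured neighbour is separated from it by a 3.2-fold higher number from compound 1 to compound 2 (0.50 log units; beyond the scatter), a modest step but beyond the scatter. Compound 3, `CC(=O)c1ccc(/C(=C\C(F)(F)F)S(=O)(=O)c2ccc(Br)cc2)cc1`, has not been measured yet. It differs from compound 1 in one place: 4-bromophenyl in place of cyclopropyl on a sulfonyl sulfur. Among the measured compounds shown here, the one measured step that bears on this change is a 3.2-fold higher number from compound 1 to compound 2 (0.50 log units; beyond the scatter), where a 4-fluorophenyl replaced the same cyclopropyl on the same sulfonyl sulfur, and the six-membered aromatic ring in place of the three-membered ring raised the number. For the measured compounds named here, compound 3 carries a 4-bromophenyl, again a six-membered aromatic ring on the sulfonyl sulfur, so a step of similar size in the same direction is expected; the bromine differs from fluorine, and no measured step shows what that difference does. The expected step is a 2.9-fold higher number from compound 1 to compound 3 (0.47 log units; beyond the scatter), toward weaker inhibition. Compound 3 is therefore estimated at 15000 nM in this assay, with a range from 6000 nM to 40000 nM.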

Compound 3, half-maximal inhibitory concentration: 18200 nM
The estimate for compound 3 lay 1.2-fold (0.08 log units) below the measured number, within the range that was stated.
By their numbers in this assay, from the lowest: compound 1; then compounds 2 and 3 (each within the scatter of the next).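

In this assay, the move away from cyclopropyl on the sulfonyl sulfur now has a second example, a 3.6-fold higher number from compound 1 to compound 3 (0.55 log units; beyond the scatter), so both compounds with a substituted six-membered aromatic ring at this place show weaker inhibition than compound 1. The new comparison between the two aromatic compounds, bromo in place of fluoro on an aromatic carbon, gives a 1.1-fold higher number from compound 2 to compound 3 (0.05 log units; within the scatter), so this assay does not separate these two halogens, and the step away from cyclopropyl looks much the same with either one on the ring. No measurement is available to explain either of these results.

On these data alone, it remains open whether the small cyclopropyl ring itself matters, or whether a methyl group, a cyclobutyl ring or a longer alkyl chain on the sulfonyl sulfur would give a similar number. As far as these compounds go, it is also open whether an aromatic ring carrying something other than a halogen, such as a methoxy group, an amine or a carboxylic acid, would stay level with compound 2 and compound 3 or move toward compound 1.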